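Amine side chain and rat oral exposure in the series

A few compounds are considered here, and "the series" means these few. Any claim that something is new, unique, unknown or untested is made for them only; others in the source may bear on it.

Compound 2 `COCCNc1nc(C)c(-c2nc3ccccc3s2)c(N[C@@H]2C[C@H](CO)[C@@H](O)[C@H]2O)n1` gives 2630 ng.h/mL in an ADME assay on the whole organism (plasma) for pharmacokinetics, with Rattus norvegicus as the target, with a stated time of 6 h, at a dose of 10 mg/kg by the oral route (on this read-out higher numbers stand for higher exposure at the dose given and lower numbers for lower exposure), the highest of the three numbers. Compound 1 `Cc1nc(NCC2CCC2)nc(N[C@@H]2C[C@H](CO)[C@@H](O)[C@H]2O)c1-c1nc2ccccc2s1` gives 228 ng.h/mL and compound 3 `Cc1nc(Nc2ccccc2)nc(N[C@@H]2C[C@H](CO)[C@@H](O)[C@H]2O)c1-c1nc2ccccc2s1` gives 742 ng.h/mL. Compound 4 `Cc1nc(NCc2ccccn2)nc(N[C@@H]2C[C@H](CO)[C@@H](O)[C@H]2O)c1-c1nc2ccccc2s1` is not yet measured; its change from compound 2 is pyridin-2-yl in place of methoxymethyl on a saturated chain carbon bound to a nitrogen on an aromatic ring. Among the compounds with values here, two measured steps bear on it. The step of a 12-fold higher number from compound 1 to compound 2 (1.06 log units; beyond the scatter) shows that the methoxymethyl group on the saturated chain carbon goes with the high number, and the step of a 3.5-fold lower number from compound 2 to compound 3 (0.55 log units; beyond the scatter) shows that an aromatic ring in place of the 2-methoxyethyl chain lowers it. Compound 4 likewise loses the methoxymethyl group and gains an aromatic ring. The expected step for compound 4 is a 3.8-fold lower number from compound 2 to compound 4 (0.57 log units; beyond the scatter), a modest drop beyond the scatter. Compound 4 is estimated at 700 ng.h/mL, within 200 ng.h/mL to 2400 ng.h/mL.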

Compound 4, area under the concentration-time curve: 1630 ng.h/mL
Estimate against measurement, compound 4: 2.3-fold (0.37 log units) below, and the stated range covers the measured number.
By their numbers in this assay, from the lowest: compound 1; then compound 3; then compounds 4 and 2 (each within the scatter of the next).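

In this assay, within the data shown here, pyridin-2-yl on the saturated chain carbon holds the number with methoxymethyl (a 1.6-fold lower number from compound 2 to compound 4 (0.21 log units; within the scatter)), so that ether group is not the only group compatible with high exposure here. Cyclobutyl on the same carbon is clearly poorer (a 7.1-fold higher number from compound 1 to compound 4 (0.85 log units; beyond the scatter)), and the directly attached phenyl also falls short of (pyridin-2-yl)methyl (a 2.2-fold higher number from compound 3 to compound 4 (0.34 log units; beyond the scatter)). No supporting data explain these differences.

Whether the ring nitrogen matters remains open, as benzyl is not among the compounds shown. Also open, from the compounds shown here alone, is how a longer chain carrying pyridin-2-yl would read.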